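This account rests on a few compounds, and the source may have more. Where it says the series, first, only, none or still open, it means among the compounds named here.

Of the compounds shown here, three of one family have been tested in an ADME assay on HEK-293T cells (Homo sapiens) for cytotoxicity, read by CCK-8 assay, with a stated time of 48 h; on this read-out lower numbers stand for higher toxicity in this test and higher numbers for lower toxicity in this test. Compound 1 `O=C(CSc1c[nH]c2ccc(Cl)cc12)Nc1ccc(Cl)c(Cl)c1` gives 42700 nM in this assay. Compound 2 `CCOc1ccccc1NC(=O)CSc1c[nH]c2cc(Cl)ccc12` reaches only a limit in this assay, namely > 100000 nM. That limit is the limit of > 100000 nM in this assay, at which 1 of the 3 values shown sits. Compound 3 `CCOc1ccccc1NC(=O)CSc1c[nH]c2cc(OC)ccc12` gives 88200 nM in this assay. From compound 2 to compound 3 the change is methoxy in place of chloro on an aromatic carbon, and it made an at least 1.1-fold lower number from compound 2 to compound 3 (0.05 log units; that floor lies within the scatter).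

Compound 4 `COc1ccc2[nH]cc(SCC(=O)Nc3ccc(Cl)c(Cl)c3)c2c1` is not yet measured. It differs from compound 1 by methoxy in place of chloro on an aromatic carbon, the same change, made at the same place, as that between compound 2 and compound 3. How the cores of compound 1 and compound 2 differ is not broken down here.

For compound 4 a step of a 1.1-fold lower number from compound 1 to compound 4 (0.03 log units; within the scatter) in this assay is expected, resting on an at least 1.1-fold lower number from compound 2 to compound 3 (0.05 log units; that floor lies within the scatter). Compound 4 is therefore estimated at 40000 nM, between 18000 nM and 90000 nM.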

Compound 4, half-maximal cytotoxic concentration: 61800 nM
For compound 4 the middle estimate is 1.5-fold (0.19 log units) below the measured one, within the range that was stated.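

In this assay methoxy in place of chloro on the core of compound 1 gives a 1.4-fold higher number from compound 1 to compound 4 (0.16 log units; within the scatter), so on this core the change moves the number no further than repeat measurements usually do. Neither step is a clear shift, yet the change cannot be called equal on the two cores: the same change on two cores in this assay, an at least 1.1-fold lower number (0.05 log units; that floor lies within the scatter) from compound 2 to compound 3 and a 1.4-fold higher number (0.16 log units; within the scatter) from compound 1 to compound 4; the limit leaves it open whether they differ. Compound 2 carries a limit and not a number, so the step on its core has only one firm end: the limit of > 100000 nM in this assay, at which 1 of the 4 values shown sits.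

Whether the change would behave alike on any further core stays open, since only two cores are shown. The compounds shown also leave open what an amine or a carboxylic acid would do on the same aromatic carbon in place of chloro.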